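The source may hold more compounds than are shown below. What is called first, only, known or untested is meant among the compounds shown, and "the series" means these compounds.

Working notes on the series. Compound 1 `CCCCCCCCCCCCCCCCCCNC(=O)Oc1c(C)cccc1C` gives 3100 nM in an assay on microsomes from intestinal mucosa for inhibition of acyl-CoA:cholesterol acyltransferase (Oryctolagus cuniculus); a higher number here means a weaker inhibitor, a lower number a stronger inhibitor; compound 2 `CCCCCCCCCCCCCCCCCCNC(=O)Nc1c(C)cccc1C` gives 610 nM; 610 nM (2 entries); compound 3 `CCCCCCCCCCCCCCCCCCNC(=O)Nc1c(C)cccc1Cl` gives 1100 nM. Compound 3 stands at the lowest of the two single numbers, with compound 1 the nearest; the step of a 2.8-fold lower number from compound 1 to compound 3 (0.45 log units; beyond the scatter) is a carbonyl-side swap. Compound 4 `CCCCCCCCCCCCCCNC(=O)Nc1c(C)cccc1Cl` differs from compound 3 only in the chain: hydrogen in place of butyl on a saturated chain carbon, ten or more bonds along the chain from an amide-type nitrogen. Within the data shown here, no measured step touches the chain, so nothing in this set speaks to its size or direction, and the expectation rests on the chain alone. A step of a 2.0-fold higher number from compound 3 to compound 4 (0.30 log units; within the scatter) is expected, leaning toward a weaker number. Compound 4 is thus estimated at 2200 nM, within 700 nM to 7000 nM.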

Compound 4, half-maximal inhibitory concentration: 70 nM
The estimate for compound 4 lay 31-fold (1.50 log units) above the measured number; measured number outside the range, below it.
By their numbers in this assay, from the lowest: compound 4; then compound 3; then compound 1.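

The chain is a position of strong effect in this assay: hydrogen in place of butyl on a saturated chain carbon, ten or more bonds along the chain from an amide-type nitrogen, gives a 16-fold lower number from compound 3 to compound 4 (1.20 log units; beyond the scatter). That step is clearly larger than the carbonyl-side swap, a 2.8-fold lower number from compound 1 to compound 3 (0.45 log units; beyond the scatter), so chain length outweighs that swap here. Nothing at hand gives a cause for this step.

On these data alone, with only these two chains, it remains open whether a shorter chain would lower the number further. As far as these compounds go, how a chain carrying an amine or a carboxylic acid would read also remains open.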